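Removing the tert-butyl group from compound 2

The source may hold more compounds than are shown below. What is called first, only, known or untested is meant among the compounds shown, and "the series" means these compounds.

Within the data shown here, compound 2 (`CC(C)(C)c1cc(/C=C/C=C/c2cc(O)cc(O)c2)ccc1O`) gives 91 nM in a functional assay on HT-22 cells (Mus musculus), read by MTT assay, with a stated time of 24 h (a higher number here means that more compound is needed for the effect, a lower number that less compound is needed), and has only one measured neighbour. Compound 1 (`CCC(CC)c1cc(/C=C/C=C/c2cc(O)cc(O)c2)ccc1O`) gives 79 nM on the same read-out, so the pair cannot be separated: the step is a 1.2-fold higher number from compound 1 to compound 2 (0.06 log units; within the scatter) and neither compound stands apart.

The next compound, compound 3 (`Oc1ccc(/C=C/C=C/c2cc(O)cc(O)c2)cc1`), has hydrogen in place of tert-butyl on an aromatic carbon, ortho to a hydroxy group.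

Among the measured compounds shown here, the one measured step bears on this change only loosely. For the measured compounds named here, it exchanged pentan-3-yl for tert-butyl, so an alkyl group stayed at this place, and no measured compound lacks one. The data therefore do not show what outright removal does. A moderate rise in this assay is still expected, held with little confidence and open to no change at all. The expected change is a 2.7-fold higher number from compound 2 to compound 3 (0.44 log units; beyond the scatter) as a rough estimate. For compound 3 the estimated value is 250 nM with an expected range from 60 nM to 1200 nM in this assay.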

Compound 3, half-maximal effective concentration: 3310 nM
Compound 3: middle estimate off by 13-fold (1.12 log units), on the low side; the whole stated range lies below it.
By their numbers in this assay, from the lowest: compounds 1 and 2 (each within the scatter of the next); then compound 3.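

In this assay the alkyl group at this place proves to matter far more than which of the two alkyl groups is present: hydrogen in place of tert-butyl gives a 36-fold higher number from compound 2 to compound 3 (1.56 log units; beyond the scatter) and hydrogen in place of pentan-3-yl gives a 42-fold higher number from compound 1 to compound 3 (1.62 log units; beyond the scatter) while the exchange of one alkyl group for the other stayed within the scatter. Both large steps end at the same compound, so they amount to one finding: among these three compounds, only the loss of the alkyl group ortho to a hydroxy group separates the values, and compound 1 and compound 2 stay together. Nothing at hand explains why removing this group has so large an effect.

The compounds shown leave open whether a methyl or an ethyl group at this place would already be enough to bring the number back to the level of compound 1 and compound 2 or would stay nearer to compound 3. On these data alone, it is also open whether a group that is not an alkyl group, such as methoxy or an amine, would stand with compound 1 and compound 2 or with compound 3.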